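The compounds below may be only part of what the source reports. "The series", "measured", "known", "first", "only" and "open" are said of these compounds alone.

In a functional assay on A549 cells (Homo sapiens) for antiproliferative activity, read by MTT assay, with a stated time of 48 h (on this read-out higher numbers stand for weaker inhibition and lower numbers for stronger inhibition), compound 1 `Cn1cc(C2=C(c3nn(CCCn4cccc4)c4ncccc34)C(=O)NC2=O)c2ccccc21` is reported only as a limit, > 100000 nM. Among the measured compounds shown here, compound 2 `Cn1cc(C2=C(c3nn(CCCCn4ccnc4)c4ncccc34)C(=O)NC2=O)c2ccccc21` gives 2380 nM, the only true number so far. Compound 3 `Cn1cc(C2=C(c3nn(CCn4ccnc4)c4ncccc34)C(=O)NC2=O)c2ccccc21` carries 1H-imidazol-1-yl in place of 2-(1H-imidazol-1-yl)ethyl, on a saturated chain carbon, two bonds along the chain from an aromatic nitrogen: 1H-imidazol-1-yl in place of 2-(1H-imidazol-1-yl)ethyl on a saturated chain carbon, two bonds along the chain from an aromatic nitrogen. For the measured compounds named here, the single measured step bearing on this is large, an at least 42-fold lower number from compound 1 to compound 2 (1.62 log units; beyond the scatter), but it changed the ring as well as the chain, so it is only a loose guide. The expected step is a 2.1-fold higher number from compound 2 to compound 3 (0.32 log units; beyond the scatter), a modest move towards weaker inhibition. For compound 3 the estimated value is 5000 nM, within a range of 1000 nM to 30000 nM.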

Compound 3, half-maximal inhibitory concentration: > 100000 nM
Compound 3 gave a limit, no number; the forecaster's own chance of this, stated with the estimate: 15%; at least 20-fold (1.30 log units) between middle value and limit.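

Cutting the chain from 4-(1H-imidazol-1-yl)butyl to 2-(1H-imidazol-1-yl)ethyl while keeping the imidazole ring gives an at least 42-fold higher number from compound 2 to compound 3 (1.62 log units; beyond the scatter) in this assay. The earlier step changed the ring and the chain together, whereas this one changes only chain length, so the imidazole ring alone does not secure a measurable number at this position. The step from compound 1 to compound 3 joins two limits and cannot be read: the limit of > 100000 nM in this assay, at which 2 of the 3 values shown sit.

From the compounds shown here alone, how a 3-(1H-imidazol-1-yl)propyl chain or a chain longer than butyl would read remains open. So does the effect of replacing the imidazole with a dimethylamino group.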